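Swapping a Cyclic Amine for a Thioether Chain

The compounds below may be only part of what the source reports. "The series", "measured", "known", "first", "only" and "open" are said of these compounds alone.

Compound 1, `CC(C(=O)NCc1ccc(C(F)(F)F)cc1N1CCC(C)(C)CC1)c1ccc(NS(C)(=O)=O)c(F)c1`: 1.3 nM
Compound 2, `Cc1ccc(N2CCN(c3cc(C(F)(F)F)ccc3CNC(=O)C(C)c3ccc(NS(C)(=O)=O)c(F)c3)CC2)cc1`: 0.7 nM
Compound 3, `COc1ccc(N2CCN(c3cc(C(F)(F)F)ccc3CNC(=O)C(C)c3ccc(NS(C)(=O)=O)c(F)c3)CC2)cc1`: 1.6 nM

All three compounds were tested in an assay on CHO cells for antagonist activity at transient receptor potential cation channel subfamily V member 1 (Homo sapiens), read by FLIPR; a higher number here means a weaker inhibitor, a lower number a stronger inhibitor. Compound 1 stands second highest of the three numbers, but its gaps to compound 2 and to compound 3 both lie within the scatter, so none of the three can be called stronger or weaker than another. For the measured compounds named here, the one measured step, a 2.3-fold higher number from compound 2 to compound 3 (0.36 log units; beyond the scatter), is modest and concerns a group on a distant aromatic ring, not the place altered below.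

Compound 4, `CCCCCCSc1cc(C(F)(F)F)ccc1CNC(=O)C(C)c1ccc(NS(C)(=O)=O)c(F)c1`, differs from compound 1 in a single place: hexylsulfanyl in place of 4,4-dimethylpiperidin-1-yl on an aromatic carbon. A ring gives way to an open chain of similar heavy-atom count, and a nitrogen gives way to a sulfur. Going by the values given here, no measured pair shares this change, so the data offer no direct guide; they show only that the shared core tolerates several groups at this place within a narrow band of values.

With nothing in the series pointing clearly either way, a small move toward a higher number is expected, as a 3.1-fold higher number from compound 1 to compound 4 (0.49 log units; beyond the scatter). Compound 4 is therefore estimated to give 4 nM in this assay, within a range from 1 nM to 25 nM.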

Compound 4, inhibition constant: 1.8 nM
Beside the measured number, compound 4's estimate is 2.2-fold (0.35 log units) above it, within the range that was stated.
By their numbers in this assay, from the lowest: compounds 2, 1, 3 and 4 (each within the scatter of the next, the first and the last beyond it).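

In this assay, putting hexylsulfanyl in place of 4,4-dimethylpiperidin-1-yl gives a 1.4-fold higher number from compound 1 to compound 4 (0.14 log units; within the scatter) and so the two groups cannot be told apart in this test. Compounds 1, 2 and 3 all carry a ring joined through nitrogen at this aromatic carbon, which is ortho to a large group and meta to a trifluoromethyl group, so they could not show whether a ring or that nitrogen is needed here; compound 4 shows that, in this assay, neither is required, since an open chain joined through sulfur gives a number that cannot be separated from that of compound 1. No measurement shown here accounts for why such different groups read alike.

The ring and the nitrogen changed together in this single step, so a hexylamino group, with nitrogen kept in an open chain, or a hexyloxy group, with oxygen as the link, would be needed to tell the two changes apart. On these data alone, how far the tolerance reaches also stays open, for example with a shorter chain such as ethylsulfanyl, or with a carboxylic acid or an amine at the far end of the chain.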